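Trading an Isopropyl for a Hydroxymethyl on the Side Chain

The source may hold more compounds than are shown below. What is called first, only, known or untested is meant among the compounds shown, and "the series" means these compounds.

Of the compounds shown here, two sharing one core have been measured in an assay on HEK293 cells for agonist activity at transient receptor potential cation channel subfamily M member 8 (Homo sapiens), read by fluorescence and calcium flux, with a stated time of 15 min; a higher number here means that more compound is needed for the effect, a lower number that less compound is needed. Compound 1 `Cc1ccc(OCC(=O)N(Cc2cccs2)c2cnn(C)c2)cc1` gives 63000 nM in this assay, and compound 2 `Cc1ccc(OCC(=O)N(Cc2cccs2)CC(C)C)cc1` gives 900 nM. Among the measured compounds shown here, compound 2 therefore stands lowest of the two numbers, and the single comparison available is the step of a 70-fold lower number from compound 1 to compound 2 (1.85 log units; beyond the scatter), where isobutyl replaced 1-methyl-1H-pyrazol-4-yl on the amide-type nitrogen. Compound 3 `Cc1ccc(OCC(=O)N(CCO)Cc2cccs2)cc1` differs from compound 2 in one place: hydroxymethyl in place of isopropyl on a saturated chain carbon bound to an amide-type nitrogen. For the measured compounds named here, no measured step alters exactly this group, yet the change runs from a purely carbon group back toward one carrying oxygen, the same broad direction that the known step reversed. The number for compound 3 is expected to rise, though by less than that earlier step, so the estimated change is a 5.6-fold higher number from compound 2 to compound 3 (0.74 log units; beyond the scatter). Compound 3 is estimated at 5000 nM, with a range from 1500 nM to 20000 nM.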

Compound 3, half-maximal effective concentration: 900 nM
Compound 3: middle estimate off by 5.6-fold (0.74 log units), on the high side; the measured number lies below the stated range.
By their numbers in this assay, from the lowest: compounds 2 and 3 (each within the scatter of the next); then compound 1.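

In this assay, the change from isobutyl to 2-hydroxyethyl on the amide-type nitrogen gives no change at the digits printed from compound 2 to compound 3 (within the scatter) even though one hydrogen-bond donor and one hydrogen-bond acceptor enter with the hydroxymethyl. So, between these two compounds, this position shows no penalty for carrying that oxygen in place of an all-carbon end. Replacing 1-methyl-1H-pyrazol-4-yl with 2-hydroxyethyl gives a 70-fold lower number from compound 1 to compound 3 (1.85 log units; beyond the scatter) and so matches the earlier step, a 70-fold lower number from compound 1 to compound 2 (1.85 log units; beyond the scatter) for isobutyl, leaving compound 1 alone at the high end of these three numbers. No measurement here explains why the two chains give the same number.

An amine or a carboxylic acid at the end of this chain could still behave differently from the hydroxymethyl. From the compounds shown here alone, a longer chain also remains open, as does a methyl ether in place of the 2-hydroxyethyl group's hydrogen-bond donor.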